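The source may hold more compounds than are shown below. What is called first, only, known or untested is meant among the compounds shown, and "the series" means these compounds.

Measured compounds:
- compound 1 `CCOc1cc(/C=C2\SC(=O)NC2=O)ccc1OCC1(C)CCc2c(C)c(OCC=C(C)C)c(C)c(C)c2O1`; in a functional assay on MCF7 cells (Homo sapiens), tested at 2.5 uM (on this read-out higher numbers stand for a weaker effect at the one concentration tested and lower numbers for a stronger effect), compound 1 gives 107%
- compound 2 `CC(C)=CCOc1c(C)c(C)c2c(c1C)CCC(C)(COc1ccc(/C=C3\SC(=O)NC3=O)cc1C)O2`; compound 2 gives 89%
- compound 3 `COc1cc(/C=C2\SC(=O)NC2=O)ccc1OCC1(C)CCc2c(C)c(OCC=C(C)C)c(C)c(C)c2O1`; compound 3 gives 95%

Compound 1 stands highest of the three numbers, so it shows the weakest effect at the single concentration. Its nearest neighbour is compound 3, with a number 12 percentage points lower from compound 1 to compound 3 (beyond the scatter), and its furthest is compound 2, with a number 18 percentage points lower from compound 1 to compound 2 (beyond the scatter). Between compounds 2 and 3 the step is a number 6 percentage points higher from compound 2 to compound 3 (within the scatter).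

Compound 4 `CC(C)=CCOc1c(C)c(C)c2c(c1C)CCC(C)(COc1ccc(/C=C3\SC(=O)NC3=O)cc1)O2` is not yet measured. It differs from compound 1 in one place: hydrogen in place of ethoxy on an aromatic carbon. The ethoxy leaves entirely and a hydrogen enters.

Within the data shown here, two measured steps bear on this, both starting from compound 1 and both altering the same ethoxy: shortening it to methoxy gave a number 12 percentage points lower from compound 1 to compound 3 (beyond the scatter), and exchanging it for methyl gave a number 18 percentage points lower from compound 1 to compound 2 (beyond the scatter). Each moved the read-out lower, beyond the scatter yet modest in size. Removing the group outright is expected to fall in the same direction and at a comparable size, so the step from compound 1 is estimated as a number 14 percentage points lower from compound 1 to compound 4 (beyond the scatter). Compound 4 is therefore expected to give 93% in this assay, with a range from 80% to 106%.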

Compound 4, a percentage reported as activity, at one concentration (the size of the read-out at that concentration, not a potency): 76%
Compound 4: middle estimate off by 17 percentage points, on the high side; measured number outside the range, below it.
By their numbers in this assay, from the lowest: compound 4; then compounds 2 and 3 (each within the scatter of the next); then compound 1.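

In this assay, hydrogen on this aromatic carbon gives a lower number than each of the three groups compared: a number 31 percentage points lower from compound 1 to compound 4 (beyond the scatter) on loss of ethoxy, a number 19 percentage points lower from compound 3 to compound 4 (beyond the scatter) on loss of methoxy and a number 13 percentage points lower from compound 2 to compound 4 (beyond the scatter) on loss of methyl. Among these compounds, compound 4 therefore shows the strongest effect of the four at the one concentration tested, a result the earlier compounds could not reveal, as all of them carry a group at this place. No available data account for this result.

On these data alone, it remains open whether fluorine, chlorine, a hydroxyl or an amine on this aromatic carbon would read lower or higher than hydrogen. As far as these compounds go, whether the same order would hold at other concentrations also remains open.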